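From fluoro to chloro on the bromo compound

The source may hold more compounds than are shown below. What is called first, only, known or untested is meant among the compounds shown, and "the series" means these compounds.

Values so far in a functional assay on HeLa cells (Homo sapiens) for antiproliferative activity, read by MTT assay, with a stated time of 48 h; on this read-out higher numbers stand for weaker inhibition and lower numbers for stronger inhibition
- compound 1 `Fc1ccc(-c2nn(-c3ccccc3)cc2-c2nc3cc(Cl)ccc3[nH]2)cc1` gives 2770 nM
- compound 2 `Fc1ccc(-c2nn(-c3ccccc3)cc2-c2nc3cc(Br)ccc3[nH]2)cc1` gives 4940 nM
- compound 3 `COc1ccc2[nH]c(-c3cn(-c4ccccc4)nc3-c3ccc(F)cc3)nc2c1` gives 7510 nM

Compound 2 lies within the scatter of both other measured compounds. The two steps are a 1.8-fold higher number from compound 1 to compound 2 (0.25 log units; within the scatter) and a 1.5-fold higher number from compound 2 to compound 3 (0.18 log units; within the scatter). Only the outer pair separates, with a 2.7-fold higher number from compound 1 to compound 3 (0.43 log units; beyond the scatter).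

Compound 4 `Clc1ccc(-c2nn(-c3ccccc3)cc2-c2nc3cc(Br)ccc3[nH]2)cc1` differs from compound 2 in one place: chloro in place of fluoro on an aromatic carbon. In words, this is chloro in place of fluoro on an aromatic carbon, para to a large group.

For the measured compounds named here, no measured step changes that place. Going by the values given here, the only halogen swap measured, made at a different place, is a 1.8-fold higher number from compound 1 to compound 2 (0.25 log units; within the scatter). On that evidence, no step beyond the scatter is expected in this assay. The estimate means an expected 1.0-fold higher number from compound 2 to compound 4 (0.01 log units; within the scatter). For compound 4 the estimated value is 5000 nM, with an expected range of 2000 nM to 12000 nM.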

Compound 4, half-maximal inhibitory concentration: 2160 nM
For compound 4 the middle estimate is 2.3-fold (0.36 log units) above the measured one, and the stated range covers the measured number.
By their numbers in this assay, from the lowest: compounds 4, 1, 2 and 3 (each within the scatter of the next, the first and the last beyond it).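

In this assay, for the compounds shown here, the change from 4-fluorophenyl to 4-chlorophenyl gives a 2.3-fold lower number from compound 2 to compound 4 (0.36 log units; beyond the scatter) and so provides the first measurement at this place, para to a large group. A single halogen swap here moves the number beyond the scatter, whereas the swap elsewhere on the molecule, a 1.8-fold higher number from compound 1 to compound 2 (0.25 log units; within the scatter), stays within it. Nothing measured here accounts for this step.

From the compounds shown here alone, whether other groups at this place, such as a methyl group or an amine, would give a lower or higher number remains open. So does whether the same swap would give a similar step on compound 1 or compound 3.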